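Piperazine Replaces Dimethylamino on the Sulfonamide Sulfur

This account rests on a few compounds, and the source may have more. Where it says the series, first, only, none or still open, it means among the compounds named here.

Going by the values given here, compound 2 `CCOC(=O)[C@@H]1CCCN(S(=O)(=O)c2ccc(S(=O)(=O)N(C)C)cc2)C1` holds the lowest of the two numbers so far: in a functional assay on MIA PaCa-2 cells (Homo sapiens) for inhibition, read by MTT assay, with a stated time of 7 days (on this read-out lower numbers stand for stronger inhibition and higher numbers for weaker inhibition), compound 2 gives 900 nM, while compound 1 `CCCN(CCC)S(=O)(=O)c1ccc(S(=O)(=O)N2CCC[C@@H](C(=O)OCC)C2)cc1` gives 2300 nM. Among the compounds with values here, the one measured step, a 2.6-fold lower number from compound 1 to compound 2 (0.41 log units; beyond the scatter), concerns the same sulfonyl position. Compound 3 `CCOC(=O)[C@@H]1CCCN(S(=O)(=O)c2ccc(S(=O)(=O)N3CCNCC3)cc2)C1` differs from compound 2 by piperazin-1-yl in place of dimethylamino on a sulfonyl sulfur. Within the data shown here, no measured step matches this exchange; the single step at this position was modest, so a change of similar size, in either direction or none beyond the scatter, is expected. For compound 3 the estimate is 1500 nM, with a range from 400 nM to 5000 nM, an expected step of a 1.7-fold higher number from compound 2 to compound 3 (0.22 log units; within the scatter).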

Compound 3, half-maximal inhibitory concentration: > 30000 nM
Compound 3: a limit, no number; the forecaster's own chance of this, stated with the estimate: 10%; at least 20-fold (1.30 log units) between middle value and limit.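

In this assay compound 3 gives no number, only a limit: the limit of > 30000 nM in this assay, at which 1 of the 3 values shown sits.

Piperazin-1-yl on the sulfonyl sulfur gives an at least 33-fold higher number from compound 2 to compound 3 (1.52 log units; beyond the scatter), and the comparison with the dipropylamino group gives an at least 13-fold higher number from compound 1 to compound 3 (1.11 log units; beyond the scatter). The earlier step at this position was modest, whereas this exchange shows that the same position can carry a large change.

The compounds shown leave open whether this change follows the six-membered ring or its second nitrogen. A morpholin-4-yl or 4-methylpiperazin-1-yl group on the same sulfur would bear on that question.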